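Solubility notes on three measured compounds and one pending

The compounds below may be only part of what the source reports. "The series", "measured", "known", "first", "only" and "open" are said of these compounds alone.

Measured so far:
compound 1 `COc1ccc(F)cc1CNCCCNc1ccnc2cc(Cc3ccc(C#N)cc3)ccc12` gives 4200 nM in a physicochemical assay for solubility, with a stated time of 18 h, at pH 7.4; a lower number here means a less soluble compound, a higher number a more soluble compound
compound 2 `COc1ccc(F)cc1CNCCCNc1ccnc2cc(-c3cccc4ccccc34)ccc12` gives 32000 nM in this assay
compound 3 `N#Cc1ccc(Cc2ccc3c(NCCCNCc4ccco4)ccnc3c2)cc1` gives 4200 nM in this assay

Two single-point changes connect these. The first is naphthalen-1-yl in place of 4-cyanobenzyl on an aromatic carbon and gives a 7.6-fold higher number from compound 1 to compound 2 (0.88 log units; beyond the scatter). The second is furan-2-yl in place of 5-fluoro-2-methoxyphenyl on a saturated chain carbon bound to an amine nitrogen and gives no change at the digits printed from compound 1 to compound 3 (within the scatter); compound 3 and compound 1 therefore sit level, and together they hold the lowest numbers of the three, with compound 2 the furthest from compound 3.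

Compound 4 `c1coc(CNCCCNc2ccnc3cc(-c4cccc5ccccc45)ccc23)c1` is not yet measured. It differs from compound 3 by naphthalen-1-yl in place of 4-cyanobenzyl on an aromatic carbon. Going by the values given here, this is the same change as the one from compound 1 to compound 2, at a place described in the same words, so the earlier step is the direct reference. The cores of the two pairs differ by furan-2-yl in place of 5-fluoro-2-methoxyphenyl on a saturated chain carbon bound to an amine nitrogen, a difference that left the number unchanged within scatter.

In this assay the expected step is a 7.1-fold higher number from compound 3 to compound 4 (0.85 log units; beyond the scatter), resting on the earlier step of a 7.6-fold higher number from compound 1 to compound 2 (0.88 log units; beyond the scatter) and on compound 3 matching compound 1 by no change at the digits printed from compound 1 to compound 3 (within the scatter). The estimate for compound 4 is 30000 nM, with a range of 10000 nM to 90000 nM expected.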

Compound 4, solubility: 32000 nM
Compound 4: middle estimate off by 1.1-fold (0.03 log units), on the low side, within the range that was stated.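

In this assay naphthalen-1-yl in place of 4-cyanobenzyl gives a 7.6-fold higher number from compound 3 to compound 4 (0.88 log units; beyond the scatter) on the core with furan-2-yl, the same size at the digits printed as a 7.6-fold higher number from compound 1 to compound 2 (0.88 log units; beyond the scatter) on the core with 5-fluoro-2-methoxyphenyl, so the change carried from one core to the other with its size intact. With naphthalen-1-yl present, furan-2-yl in place of 5-fluoro-2-methoxyphenyl gives no change at the digits printed from compound 2 to compound 4 (within the scatter) and with 4-cyanobenzyl present it gives no change at the digits printed from compound 1 to compound 3 (within the scatter), so the two changes read as independent across these four compounds. This is a single pair of cores and shows nothing for any core beyond them, and no measurement at hand bears on why the step has this size.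

Open, on these data alone, is whether the step holds when a longer chain replaces the saturated chain of the shared core. Also open, as far as these compounds go, is how a carboxylic acid or a primary amine would read on that aromatic carbon in place of naphthalen-1-yl.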